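Chloro on the hydroxamate ring of a benzamide HDAC8 inhibitor

The compounds below may be only part of what the source reports. "The series", "measured", "known", "first", "only" and "open" are said of these compounds alone.

Measured compounds:
Compound 1, `CSc1ccc(C(=O)NO)cc1NC(=O)c1ccc(-c2ccccc2)cc1`: 220 nM
Compound 2, `CCOc1ccc(C(C)=O)cc1NC(=O)c1cccc(C(=O)NO)c1`: 590 nM

Of the compounds shown here, two have been measured in an assay on isolated protein for inhibition of histone deacetylase 8 (Homo sapiens), read by fluorescence, with a stated time of 90 min; on this read-out lower numbers stand for stronger inhibition and higher numbers for weaker inhibition. Compound 1 gives 220 nM and compound 2 gives 590 nM, so compound 2 stands with the higher number of the two; the gap between them is beyond the scatter of repeated measurements. The two differ in several places at once, so no single change can be read from that gap.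

Compound 3, `CCOc1ccc(C(C)=O)cc1NC(=O)c1cc(C(=O)NO)ccc1Cl`, has not yet been measured. It differs from compound 2 in one place: chloro in place of hydrogen on an aromatic carbon. Among the compounds with values here, no measured pair shows this change on this scaffold, so no direction can be taken from the data. In this assay the step from compound 2 to compound 3 is expected to stay within the usual scatter, a 1.1-fold lower number from compound 2 to compound 3 (0.03 log units; within the scatter). Compound 3 is therefore estimated at 550 nM, with a range from 150 nM to 2000 nM.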

Compound 3, half-maximal inhibitory concentration: 220 nM
Compound 3: middle estimate off by 2.5-fold (0.40 log units), on the high side; the measured number falls inside the stated range.
By their numbers in this assay, from the lowest: compounds 1 and 3 (each within the scatter of the next); then compound 2.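

In this assay, chloro in place of hydrogen on an aromatic carbon, para to a hydroxycarbamoyl group and ortho to a large group, gives a 2.7-fold lower number from compound 2 to compound 3 (0.43 log units; beyond the scatter), so a single added heavy atom at this position moves the number on this scaffold. Within the data shown here, this is the first change that can be read on its own, as the earlier pair differed in several places at once, but it is a modest step and rests on one pair. Nothing available explains why chloro lowers the number at this position.

On these data alone, whether a fluoro, a methyl or an amine on the same carbon would move the number in the same direction remains open. As far as these compounds go, it is also open whether chloro would give a similar step on the core of compound 1.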